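This account rests on a few compounds, and the source may have more. Where it says the series, first, only, none or still open, it means among the compounds named here.

Working notes on the series, step from compound 3 to compound 4.

Within the data shown here, compound 3 `Cc1nn(-c2ccccc2C(C)C)c2c1[C@@H](c1ccc(Oc3ccccc3)cc1)S[C@@H](C)C(=O)N2` holds the highest position among the three measured members. In an assay on isolated protein for agonist activity at Bile acid receptor (Homo sapiens), read by AlphaScreen, with a stated time of 30 min (a higher number here means a larger maximal response, a lower number a smaller maximal response), compound 3 gives 174%. Compound 2 `COc1ccccc1-c1ccc([C@H]2S[C@@H](C)C(=O)Nc3c2c(C)nn3-c2ccccc2C)cc1` is the nearest, and in this assay compound 2 gives 50%, a number beyond the scatter below compound 3. Compound 1 `COc1ccccc1-n1nc(C)c2c1NC(=O)[C@H](C)S[C@@H]2c1ccc(Oc2ccccc2)cc1` is the furthest, and in this assay compound 1 gives 37%.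

Compound 4 `Cc1ccccc1-n1nc(C)c2c1NC(=O)[C@H](C)S[C@@H]2c1ccc(Oc2ccccc2)cc1` is not yet measured. It differs from compound 3 by methyl in place of isopropyl on an aromatic carbon.

Among the measured compounds shown here, one measured step bears on this change: a number 137 percentage points higher from compound 1 to compound 3 (beyond the scatter). That step shows the group at this position on the aryl attached to the core matters a great deal; methoxy leaves a small response and isopropyl a large one. Methyl has no direct comparison within the same scaffold; compound 2 carries a methyl at this position but differs elsewhere, so its value only suggests that methyl need not bring the high response of compound 3. Expected is therefore a step down in this assay, most likely beyond the scatter, a number 89 percentage points lower from compound 3 to compound 4 (beyond the scatter), with methyl landing between methoxy and isopropyl. Compound 4 is estimated at 85%, with a range from 35% to 165%.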

Compound 4, largest response reached (reported as efficacy), in percent of the reference or control that the assay uses: 118%
Estimate against measurement, compound 4: 33 percentage points below, within the range that was stated.
By their numbers in this assay, from the lowest: compound 1; then compound 2; then compound 4; then compound 3.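

In this assay, the step of a number 81 percentage points higher from compound 1 to compound 4 (beyond the scatter) and the step of a number 56 percentage points lower from compound 3 to compound 4 (beyond the scatter) place methyl clearly apart from both other groups on this aromatic carbon, so the order on the shared scaffold is methoxy, then methyl, then isopropyl. Methyl alone is therefore enough to lift the response well above that seen with methoxy, while the full response of compound 3 is tied to isopropyl. With the 2-methylphenyl held constant, the step of a number 68 percentage points higher from compound 2 to compound 4 (beyond the scatter) shows that the low response of compound 2 goes with the 2-methoxyphenyl in place of phenoxy at the far end of the molecule, and not with methyl on the aryl attached to the core; no measurement in hand gives a reason for any of these differences.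

The compounds shown leave open where an ethyl or a tert-butyl group would fall relative to methyl and isopropyl, and how a chlorine or an amine would behave on this carbon. They also leave open whether isopropyl would raise the response to the same extent with the 2-methoxyphenyl at the far end.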